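Swapping the Aryl Group on a Dimeric Indole Amide

A few compounds are considered here, and "the series" means these few. Any claim that something is new, unique, unknown or untested is made for them only; others in the source may bear on it.

Compound 1 `CN1[C@@H]2c3[nH]c4ccccc4c3C[C@H]1[C@H](C#N)N1[C@@H](CN3C(=O)c4ccccc4C3=O)c3[nH]c4ccccc4c3C[C@@H]21` and compound 2 `CN1[C@@H]2c3[nH]c4ccccc4c3C[C@H]1[C@H](C#N)N1[C@@H](CNC(=O)c3cccc(C(F)(F)F)c3)c3[nH]c4ccccc4c3C[C@@H]21` share one core and differ only in the group attached to the side chain. In a functional assay on MCF7 cells (Homo sapiens) for cytotoxicity, read by MTT assay, with a stated time of 72 h (on this read-out higher numbers stand for weaker inhibition and lower numbers for stronger inhibition), compound 1 gives 610 nM, while compound 2 gives 110 nM. Compound 2 therefore holds the lower of the two numbers, and its gap to compound 1 lies beyond the usual scatter, so it is the stronger of the pair. Compound 3 `CN1[C@@H]2c3[nH]c4ccccc4c3C[C@H]1[C@H](C#N)N1[C@@H](CNC(=O)c3ccc(Cl)cc3)c3[nH]c4ccccc4c3C[C@@H]21` keeps the amide link of compound 2 and changes only the aromatic group: 4-chlorophenyl in place of 3-(trifluoromethyl)phenyl on a carbonyl carbon. Going by the values given here, both groups are single six-membered aromatic rings of carbon on the same carbonyl carbon, and no measured pair here shows how such a swap plays out. The expected step of a 1.5-fold higher number from compound 2 to compound 3 (0.16 log units; within the scatter) is therefore small, leaning towards a slightly higher number but possibly hidden within the scatter. Compound 3 is estimated at 160 nM, within a range of 55 nM to 480 nM.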

Compound 3, half-maximal inhibitory concentration: 610 nM
Compound 3: the middle estimate sits 3.8-fold (0.58 log units) below what was measured, outside the stated range (above it).
By their numbers in this assay, from the lowest: compound 2; then compounds 1 and 3 (each within the scatter of the next).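

On this carbonyl carbon the choice of aromatic group matters: in this assay the swap gives a 5.5-fold higher number from compound 2 to compound 3 (0.74 log units; beyond the scatter), so two single aromatic rings with the same counts of hydrogen-bond donors and acceptors are not interchangeable here. The amide link alone does not secure the lower number, as there is no change at the digits printed from compound 1 to compound 3 (within the scatter), even though the groups on that side chain are built quite differently. Nothing measured here accounts for the gap between the two aromatic groups.

The swap changes both the atoms attached to the ring and where they sit, so those two changes cannot be told apart. On these data alone, how a plain phenyl group or a pyridine ring would read on the same carbonyl carbon also remains open.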